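Shortening an octyl chain to propyl on a triazole

The compounds below may be only part of what the source reports. "The series", "measured", "known", "first", "only" and "open" are said of these compounds alone.

Three compounds that share a triazole-bearing core have been characterised in a physicochemical assay for lipophilicity, measured as octanol-water partition; a lower number here means a more polar compound, a higher number a more lipophilic compound. Compound 3 `CCCCCCCCc1cn(C/C=C(\C)CCC=C(C)C)nn1` gives 6.92. Compound 2 `CCCCCCCCc1cn(CC=C(C)C)nn1` gives 4.92 in this assay, and compound 1 `CCCc1cn(C/C=C(\C)CCC=C(C)C)nn1` gives 4.5 in this assay.

Compound 3 and compound 1 differ in one place: hydrogen in place of pentyl on a saturated chain carbon, three bonds along the chain from an aromatic carbon. This change gave a number 2.42 log units lower from compound 3 to compound 1 (beyond the scatter). Compound 3 and compound 2 differ instead at the other end of the molecule, in the group on the triazole nitrogen: hydrogen in place of 3-methylbut-2-en-1-yl on a saturated chain carbon bound to a double-bonded chain carbon. Measured in the direction from compound 2 to compound 3, that change gave a number 2.00 log units higher from compound 2 to compound 3 (beyond the scatter). Going by the values given here, compound 2 and compound 1 carry both differences against each other, so no single step is drawn between them; their values stand apart, with compound 2 the higher of the two.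

Compound 4 `CCCc1cn(CC=C(C)C)nn1` has not yet been measured. It differs from compound 2 in one place: hydrogen in place of pentyl on a saturated chain carbon, three bonds along the chain from an aromatic carbon. This is the same change as that from compound 3 to compound 1, and it occurs twice among these four compounds. The step from compound 2 to compound 4 in this assay is expected to be close to a number 2.42 log units lower from compound 2 to compound 4 (beyond the scatter), resting on the earlier step of a number 2.42 log units lower from compound 3 to compound 1 (beyond the scatter) and on the value of compound 2, 4.92. Compound 4 is therefore estimated at 2.5, with a likely range from 2.1 to 2.9.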

Compound 4, partition coefficient: 2.47
Beside the measured number, compound 4's estimate is 0.03 log units above it; the measured number falls inside the stated range.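

In this assay, the change from pentyl to hydrogen on the chain gave a number 2.45 log units lower from compound 2 to compound 4 (beyond the scatter) on the core bearing 3-methylbut-2-en-1-yl, and a number 2.42 log units lower from compound 3 to compound 1 (beyond the scatter) on the core bearing the longer nitrogen group, so the two steps run the same way and are close in size. The change at the other end behaves alike: hydrogen in place of 3-methylbut-2-en-1-yl gave a number 2.03 log units lower from compound 1 to compound 4 (beyond the scatter) with the propyl chain, and read in the opposite direction the octyl pair shows a number 2.00 log units higher from compound 2 to compound 3 (beyond the scatter) as its counterpart. This shows that, among these four compounds, each change carried over from one core to the other, but it rests on only two pairs per change, says nothing of cores outside this set, and nothing shown here accounts for why the steps agree.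

What the compounds leave open is whether the same step would hold for a chain longer than octyl, or for a chain ending in an amine or a carboxylic acid. Also open, on these data alone, is whether it would hold with a benzyl group on the triazole nitrogen in place of the two groups seen here.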